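The source may hold more compounds than are shown below. What is called first, only, known or untested is meant among the compounds shown, and "the series" means these compounds.

Measured so far in an ADME assay on the whole organism for cytotoxicity, with Artemia salina as the target, with a stated time of 24 h; on this read-out lower numbers stand for an effect already at smaller amounts and higher numbers for an effect only at larger amounts of compound:
- compound 1, `Cc1ccc(/C=C/C(=O)c2ccccc2NC(=O)NS(=O)(=O)c2ccc(C)cc2)cc1`: 15.3 ug/mL
- compound 2, `Cc1ccc(S(=O)(=O)NC(=O)Nc2ccccc2C(=O)/C=C/c2cc(O)ccc2[N+](=O)[O-])cc1`: 18.3 ug/mL

Going by the values given here, compound 2 is one of only two compounds measured in this assay. Its number and that of compound 1 sit within the scatter of each other, the whole step being a 1.2-fold higher number from compound 1 to compound 2 (0.08 log units; within the scatter); no separation between the two is shown.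

Compound 3, `Cc1ccc(S(=O)(=O)NC(=O)Nc2ccccc2C(=O)/C=C/c2ccc(Cl)cc2)cc1`, is not yet measured. It differs from compound 2 in one place: 4-chlorophenyl in place of 5-hydroxy-2-nitrophenyl on a double-bonded chain carbon bound to a double-bonded chain carbon. Among the compounds with values here, the single measured step that bears on this change is the one from compound 1 to compound 2, which also exchanged the aryl group on the double-bonded chain carbon bound to a double-bonded chain carbon, and it came out as a 1.2-fold higher number from compound 1 to compound 2 (0.08 log units; within the scatter), within the scatter. Nothing in the data separates one aryl group at this place from another.

The step to compound 3 is therefore expected to stay within the scatter as well, a 1.1-fold lower number from compound 2 to compound 3 (0.06 log units; within the scatter). Compound 3 is estimated at 16 ug/mL in this assay, with a range from 8 ug/mL to 32 ug/mL.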

Compound 3, concentration for half-maximal effect: 6.92 ug/mL
The estimate for compound 3 lay 2.3-fold (0.36 log units) above the measured number; measured number outside the range, below it.
By their numbers in this assay, from the lowest: compound 3; then compounds 1 and 2 (each within the scatter of the next).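

In this assay, going by these compounds alone, the group on a double-bonded chain carbon bound to a double-bonded chain carbon now separates compounds, which the only earlier step (a 1.2-fold higher number from compound 1 to compound 2 (0.08 log units; within the scatter)) did not show. Exchanging 5-hydroxy-2-nitrophenyl for 4-chlorophenyl at this place gives a modest shift (a 2.6-fold lower number from compound 2 to compound 3 (0.42 log units; beyond the scatter)), and chloro in place of methyl on an aromatic carbon gives one of similar standing (a 2.2-fold lower number from compound 1 to compound 3 (0.34 log units; beyond the scatter)), so compound 3 holds the lowest number of the three, with both of its steps beyond the scatter, while the 4-methylphenyl and 5-hydroxy-2-nitrophenyl groups remain unseparated. No measurement at hand explains this shift.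

As far as these compounds go, whether the lower number belongs to chloro in particular or to halogens more generally stays open, and a 4-fluorophenyl or 4-bromophenyl group at this place would bear on that. Also open, from the compounds shown here alone, is how the hydroxy and nitro groups of 5-hydroxy-2-nitrophenyl each contribute, since they enter and leave together here, and how an amine or a carboxylic acid on this ring would read in this assay.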